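A few compounds are considered here, and "the series" means these few. Any claim that something is new, unique, unknown or untested is made for them only; others in the source may bear on it.

Working notes on the series. The shared core is shown in compound 1 `Cc1ccc(CSc2cc(Cl)c(C)cc2S(=O)(=O)/N=C(\N)n2nc(C)cc2-c2ccccc2)cc1`, which in a functional assay on HeLa cells (Homo sapiens) for cytotoxicity, read by MTT assay, with a stated time of 72 h (a higher number here means a weaker inhibitor, a lower number a stronger inhibitor), gives 62000 nM, the highest of the numbers so far. Compound 2 `Cc1cc(S(=O)(=O)/N=C(\N)n2nccc2-c2ccccc2)c(SCc2cccc3ccccc23)cc1Cl` differs from compound 1 at several places; in this assay compound 2 gives 3000 nM, a far lower number. Going by the values given here, no single-point step links these two compounds, so only their two values are taken as read. Compound 3 `Cc1cc(-c2ccccc2)n(/C(N)=N/S(=O)(=O)c2cc(C)c(Cl)cc2SCc2ccccc2Cl)n1` is not yet measured in this assay. It differs from compound 1 as follows: 2-chlorophenyl in place of 4-methylphenyl on a saturated chain carbon bound to a sulfur. Among the compounds with values here, no measured pair in the set shows this exchange of groups on the saturated chain carbon bound to a sulfur, so nothing measured guides the size of the step. The expected change in this assay is a 2.1-fold lower number from compound 1 to compound 3 (0.32 log units; beyond the scatter), a modest move toward a lower number, though a step within the scatter would not surprise. For compound 3 the expected value in this assay is 30000 nM, with a range from 8000 nM to 100000 nM.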

Compound 3, half-maximal inhibitory concentration: 270000 nM
Estimate against measurement, compound 3: 9.0-fold (0.95 log units) below; measured number above the stated range.
By their numbers in this assay, from the lowest: compound 2; then compound 1; then compound 3.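

In this assay the series now has its first single-point step, which shows a 4.4-fold higher number from compound 1 to compound 3 (0.64 log units; beyond the scatter) with 2-chlorophenyl in place of 4-methylphenyl on a saturated chain carbon bound to a sulfur. This position therefore responds to the group it carries, even though the two groups match in heavy atom count, each hold one six-membered aromatic ring of carbon only, and have no hydrogen-bond donors or acceptors. No measurement on hand explains the step. This single pair does not separate the effect of adding the chlorine from that of losing the methyl, so a plain phenyl or a 4-chlorophenyl at this place remains an open comparison. Also open, on these data alone, is whether a carboxylic acid or an amine on this ring would move the number in either direction.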